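A smaller aryl on the amide nitrogen, same outlook

This account rests on a few compounds, and the source may have more. Where it says the series, first, only, none or still open, it means among the compounds named here.

Compound 1 `N#Cc1c(C2CCCCC2)nc(SCC(=O)O)[nH]c1=O` carries a carboxylic acid on the shared core. In an assay on isolated protein for inhibition of Rap guanine nucleotide exchange factor 4 (Homo sapiens), read by fluorescence and cAMP accumulation (a lower number here means a stronger inhibitor, a higher number a weaker inhibitor), compound 1 gives only a limit of > 300000 nM. Compound 2 `N#Cc1c(C2CCCCC2)nc(SCC(=O)Nc2ccccc2)[nH]c1=O` turns that acid into an anilide, and in this assay compound 2 again gives only a limit of > 300000 nM. Compound 3 `Cc1cc(C)c(NC(=O)CSc2nc(C3CCCCC3)c(C#N)c(=O)[nH]2)c(C)c1` bears a trimethylated ring on the same nitrogen, and in this assay compound 3 likewise gives only a limit of > 300000 nM. The two steps a step that the two limits leave unreadable from compound 1 to compound 2 and a step that the two limits leave unreadable from compound 2 to compound 3 are therefore of unreadable size, all three values sitting at the limit of > 300000 nM in this assay, at which 3 of the 3 values shown sit. Compound 4 `Cc1ccc(NC(=O)CSc2nc(C3CCCCC3)c(C#N)c(=O)[nH]2)cc1` differs from compound 3 by 4-methylphenyl in place of 2,4,6-trimethylphenyl on an amide-type nitrogen. Since no aryl variant here rises above the limit, compound 4 is expected to remain there too, with a number no higher from compound 3 to compound 4 (the limit leaves the size open) meaning no readable change. The estimate for compound 4 is 300000 nM, spanning 100000 nM to 1000000 nM.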

Compound 4, half-maximal inhibitory concentration: > 300000 nM
Compound 4 gave a limit, no number; the forecaster's own chance of this, stated with the estimate: 85%; the middle value lies on the limit itself.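

Compound 4 gives only a limit, > 300000 nM, so its steps from compound 1, compound 2 and compound 3 cannot be read. The compounds shown leave open which change to the shared core, if any, would give a measurable inhibitory value.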